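This account rests on a few compounds, and the source may have more. Where it says the series, first, only, none or still open, it means among the compounds named here.

Measured compounds:
- compound 1, `NS(=O)(=O)c1cccc(/N=C2\NC(=O)/C(=C3/C(=O)Nc4ccc(Br)cc43)S2)c1` — in a functional assay on MCF7 cells (Homo sapiens) for antiproliferative activity, read by MTT assay (on this read-out higher numbers stand for weaker inhibition and lower numbers for stronger inhibition), compound 1 gives > 200000 nM
- compound 2, `Cc1ccc2c(c1)/C(=C1/S/C(=N/c3ccc(S(N)(=O)=O)cc3)NC1=O)C(=O)N2` — in this assay compound 2 gives > 200000 nM

Both values shown for the series are limits of the assay rather than numbers. For compound 1 the value in this assay is a limit, so its standing among the measured compounds cannot be placed more closely than that; the other value shown is a limit as well, and (the limit of > 200000 nM in this assay, at which 2 of the 2 values shown sit). Within the data shown here, no step between measured compounds that differ in one place is available.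

Compound 3, `COc1ccc2c(c1)/C(=C1/S/C(=N/c3cccc(S(N)(=O)=O)c3)NC1=O)C(=O)N2`, is the next compound to be measured in this assay. Against compound 1 the change is methoxy in place of bromo on an aromatic carbon. Among the measured compounds shown here, with both measured compounds sitting at the limit, no direction for the step in this assay can be read from the data. The expectation for compound 3 is that the step of a number no higher from compound 1 to compound 3 (the limit leaves the size open) is none beyond the scatter. Compound 3 is therefore expected to give 200000 nM in this assay, within 50000 nM to 400000 nM, most likely again as a limit.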

Compound 3, half-maximal inhibitory concentration: > 200000 nM
Compound 3: only a limit was reported; the forecaster's own chance of this, stated with the estimate: 75%; the middle value lies on the limit itself.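

In this assay compound 3 gives > 200000 nM as a limit and not a number. Among these compounds, no step between compound 1 and compound 3 can be read from this: the limit of > 200000 nM in this assay, at which 3 of the 3 values shown sit. The compounds shown leave open whether any change on the shared core gives a measurable antiproliferative value.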